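Amino in place of bromo: from compound 3 to compound 4

The compounds below may be only part of what the source reports. "The series", "measured", "known", "first", "only" and "open" are said of these compounds alone.

Measured compounds in a functional assay on U-251 cells (Homo sapiens) for antiproliferative activity, read by MTT assay, with a stated time of 48 h; on this read-out lower numbers stand for stronger inhibition and higher numbers for weaker inhibition:
compound 1 `COc1ccc(-c2nc3cccc(-c4cc(OC)c(OC)c(OC)c4)c3o2)cc1` — > 25000 nM, a limit of the assay
compound 2 `COc1cccc(-c2nc3cccc(-c4cc(OC)c(OC)c(OC)c4)c3o2)c1` — > 25000 nM, a limit of the assay
compound 3 `COc1cc(-c2cccc3nc(-c4ccc(Br)cc4)oc23)cc(OC)c1OC` — > 25000 nM, a limit of the assay

Compound 3 stands at the ceiling of this assay: its value is a limit and not a number, and nothing separates it from the other two. (the limit of > 25000 nM in this assay, at which 3 of the 3 values shown sit). Because of this the three steps a step that the two limits leave unreadable from compound 1 to compound 2, a step that the two limits leave unreadable from compound 1 to compound 3 and a step that the two limits leave unreadable from compound 2 to compound 3 are unreadable in both size and direction.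

Compound 4 `COc1cc(-c2cccc3nc(-c4ccc(N)cc4)oc23)cc(OC)c1OC` differs from compound 3 by amino in place of bromo on an aromatic carbon. Going by the values given here, no measured step concerns an amino group, and none of the measured steps could be read at all, so there is no precedent for the size or direction of the change. The step of an at least 1.2-fold lower number from compound 3 to compound 4 (0.09 log units; that floor lies within the scatter) is therefore expected to be small or absent, with a real chance that compound 4 is again reported only as a limit. Compound 4 is estimated at 20000 nM, in the range 3000 nM to 25000 nM, in this assay.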

Compound 4, half-maximal inhibitory concentration: 1040 nM
For compound 4 the middle estimate is 19-fold (1.28 log units) above the measured one, outside the stated range (below it).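

In this assay this position, para to a large group, proves sensitive to its substituent: amino in place of bromo gives an at least 24-fold lower number from compound 3 to compound 4 (1.38 log units; beyond the scatter) and leaves compound 4 as the only compound shown with a value off the ceiling. The picture is the same against the two methoxy compounds, with an at least 24-fold lower number from compound 1 to compound 4 (1.38 log units; beyond the scatter) for amino in place of methoxy and an at least 24-fold lower number from compound 2 to compound 4 (1.38 log units; beyond the scatter) for 4-aminophenyl in place of 3-methoxyphenyl. The steps among compound 1, compound 2 and compound 3 remain unreadable, and the three new steps are floors and not full sizes because one end of each is a limit: the limit of > 25000 nM in this assay, at which 3 of the 4 values shown sit.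

Still open, on these data alone, is how much of this gain depends on the free amino group, which a dimethylamino group, an acetamide or a hydroxyl on the same carbon would help to separate. Also open, as far as these compounds go, is whether a 3-aminophenyl group would keep the activity seen with the 4-aminophenyl group.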